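Dimethylphenyl in place of dimethoxyphenyl on the enone arm

The source may hold more compounds than are shown below. What is called first, only, known or untested is meant among the compounds shown, and "the series" means these compounds.

Compound 3 `COc1ccc(/C=C/C(=O)c2ccc(NC(=O)CN3CCN(c4cc5c(cc4F)c(=O)c(C(=O)O)cn5C4CC4)CC3)cc2)cc1OC` stands highest of the three numbers in an assay on isolated protein for inhibition of DNA topoisomerase 1 (Homo sapiens), with a stated time of 30 min, tested at 100 uM (on this read-out higher numbers stand for a stronger effect at the one concentration tested and lower numbers for a weaker effect), with 73.2%. Compound 2 `O=C(CN1CCN(c2cc3c(cc2F)c(=O)c(C(=O)O)cn3C2CC2)CC1)Nc1ccc(C(=O)/C=C/c2ccccc2Cl)cc1` gives 70.8%, and a number 2.4 percentage points higher from compound 2 to compound 3 (within the scatter). Compound 1 `O=C(CN1CCN(c2cc3c(cc2F)c(=O)c(C(=O)O)cn3C2CC2)CC1)Nc1ccc(C(=O)/C=C/c2ccccc2)cc1` gives 57.2%. Compound 4 `Cc1ccc(/C=C/C(=O)c2ccc(NC(=O)CN3CCN(c4cc5c(cc4F)c(=O)c(C(=O)O)cn5C4CC4)CC3)cc2)c(C)c1` differs from compound 3 by 2,4-dimethylphenyl in place of 3,4-dimethoxyphenyl on a double-bonded chain carbon bound to a double-bonded chain carbon. Within the data shown here, the steps that bear on this change are a number 16 percentage points higher from compound 1 to compound 3 (beyond the scatter) and a number 13.6 percentage points higher from compound 1 to compound 2 (beyond the scatter), both showing that a substituted phenyl at this place gave a modestly higher number than the unsubstituted phenyl of compound 1, while the two substituted phenyls of compound 2 and compound 3 lie within the scatter of each other. A small downward step, within or just beyond the scatter, is therefore expected, namely a number 8.2 percentage points lower from compound 3 to compound 4 (within the scatter). Compound 4 is estimated to give 65% in this assay, between 50% and 78%.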

Compound 4, a percentage reported as inhibition, at one concentration (the size of the read-out at that concentration, not a potency): 85.1%
Estimate against measurement, compound 4: 20.1 percentage points below; measured number above the stated range.
By their numbers in this assay, from the lowest: compound 1; then compounds 2 and 3 (each within the scatter of the next); then compound 4.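

In this assay, the 2,4-dimethylphenyl of compound 4 stands clear of both earlier substituted phenyls (a number 11.9 percentage points higher from compound 3 to compound 4 (beyond the scatter); a number 14.3 percentage points higher from compound 2 to compound 4 (beyond the scatter)), although those two lay within the scatter of each other. The distance from the unsubstituted phenyl grows as well (a number 27.9 percentage points higher from compound 1 to compound 4 (beyond the scatter)), so the kind of substituted phenyl on this double-bonded chain carbon matters, and compound 4 gives the highest number of the four. Nothing measured here accounts for this difference.

As far as these compounds go, compound 3 and compound 4 differ in both the substituents and their placing, so the contribution of each remains open. Also open, from the compounds shown here alone, is how a single methyl group, an amine or a carboxylic acid on this phenyl would compare.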